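Moving One Chlorine on a Series Stuck at the Limit

A few compounds are considered here, and "the series" means these few. Any claim that something is new, unique, unknown or untested is made for them only; others in the source may bear on it.

Compound 3 `O=C(OCc1ccccc1)N1CCN(C(=S)SCc2cn(Cc3ccc(Cl)c(Cl)c3)nn2)CC1` carries a 3,4-dichlorophenyl group on a saturated chain carbon bound to an aromatic nitrogen. In a functional assay on PC-3 cells (Homo sapiens) for inhibition, read by MTT assay, with a stated time of 72 h (a lower number here means a stronger inhibitor, a higher number a weaker inhibitor), compound 3 gives only a limit, > 128000 nM. Compound 2 `COc1ccc(Cn2cc(CSC(=S)N3CCN(C(=O)OCc4ccccc4)CC3)nn2)cc1` has 4-methoxyphenyl at that place, and in this assay compound 2 also gives only a limit, > 128000 nM. The step that the two limits leave unreadable from compound 2 to compound 3 cannot be sized because of the limit of > 128000 nM in this assay, at which 2 of the 3 values shown sit. Compound 1 `S=C(SCc1cn(Cc2ccc(Cl)c(Cl)c2)nn1)N1CCNCC1` has no result in this assay, "not determined" (no result reported). So compound 3 stands at the same limit as the one other compound with a reading, and no measured step has a readable size.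

Compound 4 `O=C(OCc1ccccc1)N1CCN(C(=S)SCc2cn(Cc3ccccc3Cl)nn2)CC1` differs from compound 3 in one place: 2-chlorophenyl in place of 3,4-dichlorophenyl on a saturated chain carbon bound to an aromatic nitrogen. Within the data shown here, no measured step bears on this change with a readable size, so the expectation rests on compound 3 alone. Compound 4 is expected to stay near the limit of this assay, with an estimated step that the limit leaves unreadable from compound 3 to compound 4 and no change beyond scatter. The estimate for compound 4 is 150000 nM, expected to fall between 40000 nM and 500000 nM.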

Compound 4, half-maximal inhibitory concentration: > 128000 nM
Compound 4 ended at the assay's limit; the forecaster's own chance of this, stated with the estimate: 80%; the middle value lies beyond the limit too.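

In this assay compound 2, compound 3 and compound 4 each give only a limit, so the steps among them cannot be read: (the limit of > 128000 nM in this assay, at which 3 of the 4 values shown sit). From the compounds shown here alone, whether any group at this place on the saturated chain carbon can give a readable value stays open.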